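Aryl group on the ring amine nitrogen: notes toward compound 3

The source may hold more compounds than are shown below. What is called first, only, known or untested is meant among the compounds shown, and "the series" means these compounds.

Measured so far:
compound 1 `O=C(CN1CCN(c2ccccc2)CC1)Nc1nc2ccccc2[nH]1` gives 32.2%
compound 2 `O=C(CN1CCN(c2ccccn2)CC1)Nc1nc2ccccc2[nH]1` gives 57.3%

Both numbers come from a functional assay, read by spectrophotometry, with a stated time of 30 min, tested at 100 ug/mL; a higher number here means a stronger effect of the compound at the concentration tested, a lower number a weaker effect. Going by the values given here, compound 2 stands highest of the two values shown, with compound 1 the nearest and clearly lower; the one step measured runs a number 25.1 percentage points higher from compound 1 to compound 2 (beyond the scatter).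

Compound 3 `O=C(CN1CCN(c2ccc([N+](=O)[O-])cc2)CC1)Nc1nc2ccccc2[nH]1` has not been measured. It differs from compound 2 by 4-nitrophenyl in place of pyridin-2-yl on an amine nitrogen in a ring. Among the compounds with values here, no measured step covers a nitrophenyl group on this ring nitrogen. Within the data shown here, the only step in hand concerns the aryl group at the same place, where the phenyl of compound 1 sits well below the pyridin-2-yl of compound 2, so a move away from pyridin-2-yl is expected to cost activity in this assay rather than add to it, though by how much is open. The step is estimated at a number 17.3 percentage points lower from compound 2 to compound 3 (beyond the scatter). Compound 3 is therefore expected to reach about 40%, somewhere between 20% and 62%.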

Compound 3, a percentage reported as activity, at one concentration (the size of the read-out at that concentration, not a potency): 51.7%
Estimate against measurement, compound 3: 11.7 percentage points below; low and high end bracket the measured number.
By their numbers in this assay, from the lowest: compound 1; then compounds 3 and 2 (each within the scatter of the next).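

In this assay, the read-out at this amine nitrogen in a ring does not depend on pyridin-2-yl alone: the data show a number 5.6 percentage points lower from compound 2 to compound 3 (within the scatter) for 4-nitrophenyl in place of pyridin-2-yl, so neither group can be ranked over the other. The phenyl of compound 1 also responds to substitution, with nitro in place of hydrogen on an aromatic carbon giving a number 19.5 percentage points higher from compound 1 to compound 3 (beyond the scatter) and thus no need for a ring nitrogen in the aryl group to clear the value of the unsubstituted phenyl. No available evidence explains either step.

On these data alone, whether this gain is specific to nitro remains open, as an amine, a methoxy group or a carboxylic acid in its place would test. Also open, as far as these compounds go, is whether an aryl group is needed at this nitrogen at all, which a benzyl or acetyl group there would address.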